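From trifluoromethyl to methoxy in a growth inhibition assay

The compounds below may be only part of what the source reports. "The series", "measured", "known", "first", "only" and "open" are said of these compounds alone.

Within the data shown here, in a functional assay on HaCaT cells (Homo sapiens) for inhibition, read by sulforhodamine B assay, with a stated time of 48 h (a higher number here means a weaker inhibitor of growth, a lower number a stronger inhibitor of growth), compound 1 (`CC1(/C=C/c2ccccc2C(F)(F)F)C=CC(=O)O1`) gives 12700 nM as the lower of the two numbers measured so far. Compound 2 (`COc1cc(/C=C/C2(C)C=CC(=O)O2)cc(OC)c1OC`) gives 175000 nM and that gap lies beyond the scatter. Compound 3 (`COc1ccccc1/C=C/C1(C)C=CC(=O)O1`) has not yet been measured. It differs from compound 1 by a single change (methoxy in place of trifluoromethyl on an aromatic carbon): methoxy in place of trifluoromethyl on an aromatic carbon, ortho to a group of 9 heavy atoms. Among the measured compounds shown here, no pair of measured compounds differs in one place only, so the data offer no direct guide to the size of this step. For the measured compounds named here, the one measured compound with methoxy groups is compound 2 at 175000 nM and it differs from compound 3 in more than one place, so it gives only a weak hint of direction. In this assay the expected change is a 3.1-fold higher number from compound 1 to compound 3 (0.50 log units; beyond the scatter) as a moderate move to a higher number, beyond the scatter, which would mean a weaker inhibitor of growth. For compound 3 the estimated value is 40000 nM with an expected range from 12000 nM to 130000 nM once it is measured.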

Compound 3, concentration for total growth inhibition: 30800 nM
For compound 3 the middle estimate is 1.3-fold (0.11 log units) above the measured one; the measured number falls inside the stated range.
By their numbers in this assay, from the lowest: compound 1; then compound 3; then compound 2.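

In this assay, among these compounds, this is the first direct reading of a single change at this place: a 2.4-fold higher number from compound 1 to compound 3 (0.38 log units; beyond the scatter) when methoxy replaces trifluoromethyl on an aromatic carbon, ortho to a group of 9 heavy atoms. Among the compounds shown here, until now, the only comparison available was between compounds that differed in more than one place, whereas this step isolates one substitution on the shared core and shows that it moves the number modestly, in the direction of a weaker inhibitor of growth. Nothing measured here accounts for the size or direction of this step.

One step cannot show whether the same exchange would give a similar change at other places on the aromatic ring or in a different substitution pattern, and compound 2 provides no separate reading of any one of its methoxy groups. From the compounds shown here alone, it also remains open how this place would respond to a group of a different kind, such as an amine, a carboxylic acid or a longer alkoxy chain, so the step gives no trend across substituents.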